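A few compounds are considered here, and "the series" means these few. Any claim that something is new, unique, unknown or untested is made for them only; others in the source may bear on it.

Compound 1 `C/C=C/C(=O)Nc1cccc(Cn2nc(-c3ccc(Oc4ccccc4)cc3)cc2C(=O)O)c1` carries a (prop-1-en-1-yl)carbonyl group on an amide-type nitrogen. In a functional assay on Maver1 cells (Homo sapiens) for inhibition, read by luminescence and CellTiter-Glo, with a stated time of 72 h (a lower number here means a stronger inhibitor, a higher number a weaker inhibitor), compound 1 gives 31600 nM. Compound 3 `C=CC(=O)Nc1cccc(Cn2nc(-c3ccc(Oc4ccccc4)cc3)cc2C(=O)O)c1` differs from it in one place: vinyl in place of prop-1-en-1-yl on a carbonyl carbon. In this assay compound 3 gives 37400 nM, and the step of a 1.2-fold higher number from compound 1 to compound 3 (0.07 log units; within the scatter) shows that this exchange leaves the result essentially where it was.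

Compound 2 `C/C=C/C(=O)N1CCCC(n2nc(-c3ccc(Oc4ccccc4)cc3)cc2CO)C1` is built on a different core, and the difference between the two cores is not broken down here. For compound 2, this assay reports only a limit, > 60000 nM, and not a number; this is the limit of > 60000 nM in this assay, at which 1 of the 3 values shown sits.

Compound 4 `C=CC(=O)N1CCCC(n2nc(-c3ccc(Oc4ccccc4)cc3)cc2CO)C1` has not yet been measured in this assay. It stands to compound 2 as compound 3 stands to compound 1: vinyl in place of prop-1-en-1-yl on a carbonyl carbon. The surroundings are not identical word for word: in compound 1 the carbonyl carbon's other neighbour is an amide-type nitrogen, whereas in compound 2 it is an amide-type nitrogen in a ring, so the two changes are the same kind of change rather than the same change.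

The step expected from compound 2 to compound 4 is a step that the limit leaves unreadable from compound 2 to compound 4, set beside the measured 1.2-fold higher number from compound 1 to compound 3 (0.07 log units; within the scatter), on the reading that swapping prop-1-en-1-yl for vinyl did little for compound 1. Compound 2 starts from a limit, > 60000 nM, so little room for a measured number is expected. Compound 4 is therefore estimated to give about 80000 nM in this assay, most likely within 40000 nM to 200000 nM, and quite possibly again only a limit.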

Compound 4, half-maximal inhibitory concentration: 30500 nM
Compound 4: middle estimate off by 2.6-fold (0.42 log units), on the high side; the measured number lies below the stated range.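

On the core of compound 2, putting vinyl in place of prop-1-en-1-yl on the carbonyl carbon gives an at least 1.9-fold lower number from compound 2 to compound 4 (0.29 log units; that floor lies within the scatter) in this assay. As far as these compounds go, compound 2 is recorded in this assay only as a limit, > 60000 nM, and not as a number, and the true size of this step therefore stays unknown. The result shows that a vinyl compound gives a measured number on both cores, compound 3 on one and compound 4 on the other, but it does not show whether the change acts alike or differently on the two cores: the same change on two cores in this assay, a 1.2-fold higher number (0.07 log units; within the scatter) from compound 1 to compound 3 and an at least 1.9-fold lower number (0.29 log units; that floor lies within the scatter) from compound 2 to compound 4; the limit leaves it open whether they differ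

The compounds shown leave open what happens when the group on the carbonyl carbon is something other than vinyl or prop-1-en-1-yl, such as a longer chain or a chain that carries an amine, and whether either core can give a much lower number in this kind of test. The two cores also differ in more than one place, and no single change separating them can be read from these compounds, which leaves the contribution of each difference unresolved.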